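Chloro for Methoxy: From Compound 3 to Compound 4

The source may report more compounds than this note shows. Statements on the series, on what has been measured and on what is new or still open speak of the compounds shown alone.

Of the compounds shown here, three with a shared core have been tested. Compound 1 `COc1cc(/C=C/C(=O)c2cccc(-n3cc(-c4ccccc4)[nH]c3=O)c2)ccc1O` gives 2020 nM in a functional assay on NCI-H23 cells (Homo sapiens) for inhibition; a lower number here means a stronger inhibitor of growth, a higher number a weaker inhibitor of growth; compound 2 `O=C(/C=C/c1cccc(O)c1)c1cccc(-n2cc(-c3ccc(Cl)cc3)[nH]c2=O)c1` gives 2780 nM; compound 3 `COc1ccc(-c2cn(-c3cccc(C(=O)/C=C/c4ccc(O)c(OC)c4)c3)c(=O)[nH]2)cc1` gives 2850 nM. Compound 3 thus holds the highest of the three numbers, yet all three lie within the scatter of one another, so no order among them can be claimed. Compound 4 `COc1cc(/C=C/C(=O)c2cccc(-n3cc(-c4ccc(Cl)cc4)[nH]c3=O)c2)ccc1O` is not yet measured. It differs from compound 3 by chloro in place of methoxy on an aromatic carbon. Among the measured compounds shown here, the only measured single step on that ring, a 1.4-fold higher number from compound 1 to compound 3 (0.15 log units; within the scatter), stayed within the scatter. Compound 2 also carries chloro, and its number sits alongside that of compound 3. Compound 4 is therefore expected to show a 1.1-fold lower number from compound 3 to compound 4 (0.04 log units; within the scatter), nothing beyond the scatter, with an estimate of 2600 nM and a range from 1200 nM to 5500 nM.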

Compound 4, concentration for 50% growth inhibition: 3180 nM
The estimate for compound 4 lay 1.2-fold (0.09 log units) below the measured number; measured number inside the range.
By their numbers in this assay, from the lowest: compounds 1, 2, 3 and 4 (each within the scatter of the next).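

In this assay, this position on the ring has now carried hydrogen, methoxy and chloro without any separation: going from 4-methoxyphenyl to 4-chlorophenyl gives a 1.1-fold higher number from compound 3 to compound 4 (0.05 log units; within the scatter), and chloro in place of hydrogen gives a 1.6-fold higher number from compound 1 to compound 4 (0.20 log units; within the scatter). With chloro held constant, 4-hydroxy-3-methoxyphenyl in place of 3-hydroxyphenyl gives a 1.1-fold higher number from compound 2 to compound 4 (0.06 log units; within the scatter), so that change also shows no effect beyond the scatter. Nothing measured here points to a cause.

As far as these compounds go, whether an amine or a carboxylic acid at this position would move the number beyond the scatter remains open.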